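The source may hold more compounds than are shown below. What is called first, only, known or untested is meant among the compounds shown, and "the series" means these compounds.

Working notes on the series, all values from a functional assay on U-87MG ATCC cells for antiproliferative activity against U-87 MG (Homo sapiens), read by spectrophotometry, with a stated time of 2 days; a lower number here means a stronger inhibitor of growth, a higher number a weaker inhibitor of growth. Compound 1 `CC(=O)N1CCN(c2ccc(Nc3ncc(C(F)(F)F)c(N4Cc5cccc(N(C)S(C)(=O)=O)c5C4)n3)cc2)CC1` gives 22100 nM, and compound 2 `COc1cc(N2CCN(C(C)=O)CC2)ccc1Nc1ncc(C(F)(F)F)c(N2Cc3cccc(N(C)S(C)(=O)=O)c3C2)n1` gives 4700 nM. Compound 3 `CN(c1cccc2c1CN(c1nc(Nc3cc(C(F)(F)F)cc(C(F)(F)F)c3)ncc1C(F)(F)F)C2)S(C)(=O)=O` gives 16800 nM. That value lies within the scatter of the value for compound 1 and beyond the scatter of the lower value for compound 2, so compound 3 sits in the upper group of these three numbers.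

The next structure is compound 4 `CN(c1cccc2c1CN(c1nc(Nc3cccc(C(F)(F)F)c3)ncc1C(F)(F)F)C2)S(C)(=O)=O`, with this change from compound 3: hydrogen in place of trifluoromethyl on an aromatic carbon. This is hydrogen in place of trifluoromethyl on an aromatic carbon, and the other trifluoromethyl group stays.

For the measured compounds named here, only one measured step is available: a 4.7-fold lower number from compound 1 to compound 2 (0.67 log units; beyond the scatter), a modest change for methoxy in place of hydrogen on an aromatic carbon. It bears only loosely, since it involves a different group on a different parent. No measured pair removes a trifluoromethyl group, so the direction of the change is not shown by the data. A step of modest size at most is the reasonable expectation, with no change beyond the scatter as the likeliest outcome.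

The expected step is a 1.1-fold lower number from compound 3 to compound 4 (0.05 log units; within the scatter). For compound 4 the estimated value is 15000 nM, with an expected range of 6000 nM to 32000 nM.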

Compound 4, concentration for 50% growth inhibition: > 30000 nM
Compound 4: only a limit was reported (the forecaster's own chance of this, stated with the estimate: 10%); middle value at least 2.0-fold (0.30 log units) away from the limit.
By their numbers in this assay, from the lowest: compound 2; then compounds 3 and 1 (each within the scatter of the next). At a limit, above all of these: compound 4.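

In this assay compound 4 gives > 30000 nM, which is a limit of the assay and not a number. For the compounds shown here, the step is an at least 1.7-fold higher number from compound 3 to compound 4 (0.25 log units; that floor lies within the scatter), so on this aromatic carbon, meta to the remaining trifluoromethyl group, hydrogen in place of trifluoromethyl brings no lower number, and the second trifluoromethyl group is the first feature of this aryl ring whose replacement has been tested; even so, the floor of the step does not establish a real loss. The size of any change cannot be read from this pair, and the result rests on a single reading at the top of the measurable range: the limit of > 30000 nM in this assay, at which 1 of the 4 values shown sits.

Still open, as far as these compounds go, is whether any other group on this carbon, such as a nitrile, a chlorine atom, an amine or a carboxylic acid, would bring the number down or leave it where compound 3 stands. Also open is whether the gain seen with methoxy in a 4.7-fold lower number from compound 1 to compound 2 (0.67 log units; beyond the scatter) would carry over to the parent of compound 3 or compound 4, since no such pair is shown.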